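The source may hold more compounds than are shown below. What is called first, only, known or untested is meant among the compounds shown, and "the series" means these compounds.

The measured compounds:
compound 1 `COCOc1ccc(CN(Cc2ccc(C(C)(C)C)cc2)Cc2cc3cc(C)ccc3[nH]c2=O)cc1`, 6400 nM
compound 2 `Cc1ccc2[nH]c(=O)c(CN(Cc3ccc(SC(F)(F)F)cc3)Cc3ccc(C(C)(C)C)cc3)cc2c1`, > 5000 nM

In a toxicity assay on MDCK cells (Canis lupus familiaris) for cytotoxicity, read by crystal violet staining, with a stated time of 48 h (a lower number here means that less compound is tolerated, a higher number that more compound is tolerated), compound 1 gives 6400 nM. For compound 2 this assay reports only a limit, > 5000 nM. The step that the limit leaves unreadable from compound 1 to compound 2 therefore cannot be read, because the limit of > 5000 nM in this assay, at which 1 of the 2 values shown sits, hides its size. Compound 3 `Cc1ccc2[nH]c(=O)c(CN(Cc3ccc(C(C)(C)C)cc3)[C@H](CO)c3ccccc3)cc2c1` differs from compound 2 by 2-hydroxy-1-phenylethyl in place of 4-((trifluoromethyl)sulfanyl)benzyl on an amine nitrogen. No readable measured step bears on this exchange, so compound 2 stands as a limit and nothing more. The expected step is a step that the limit leaves unreadable from compound 2 to compound 3, with no direction beyond the scatter. Compound 3 is estimated at 8000 nM, between 3000 nM and 30000 nM.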

Compound 3, half-maximal cytotoxic concentration: > 10000 nM
Compound 3: no number, only a limit (the forecaster's own chance of this, stated with the estimate: 55%); middle value at least 1.2-fold (0.09 log units) from the limit.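

In this assay compound 3 gives > 10000 nM as a limit and not a number, with 2-hydroxy-1-phenylethyl bringing a hydrogen-bond donor and a defined stereocentre onto the amine nitrogen. Set against 4-(methoxymethoxy)benzyl, this exchange gives an at least 1.5-fold higher number from compound 1 to compound 3 (0.19 log units; that floor lies within the scatter) and shows no lower number at this place. The steps that involve compound 2 cannot be read, because its value is also a limit: the limit of > 5000 nM in this assay, at which 1 of the 3 values shown sits.

On these data alone, how far the true value of compound 3 lies past its limit stays open. So does whether an amine or a carboxylic acid in place of the hydroxyl would keep the number this high.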